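Cytotoxicity of the shared core with varied amine substituents

The source may report more compounds than this note shows. Statements on the series, on what has been measured and on what is new or still open speak of the compounds shown alone.

Compound 1 `O=c1nc(N2CCN(NC3CCCCC3)CC2)sc2c([N+](=O)[O-])cc(C(F)(F)F)cc12` was examined in an ADME assay on Vero cells (Chlorocebus sabaeus) for cytotoxicity, read by MTT assay, with a stated time of 72 h; a lower number here means that less compound is tolerated, a higher number that more compound is tolerated. In this assay compound 1 gives > 64 ug/mL, which is a limit of the assay and not a number. Compound 2 `O=c1nc(N2CCN(NCC3CCCCC3)CC2)sc2c([N+](=O)[O-])cc(C(F)(F)F)cc12` carries cyclohexylmethyl in place of cyclohexyl on an amine nitrogen; in this assay compound 2 gives 29.3 ug/mL. From the compounds shown here alone, the step between them is an at least 2.1-fold lower number from compound 1 to compound 2 (0.33 log units; beyond the scatter); its full size is unknown, as it rests on (the limit of > 64 ug/mL in this assay, at which 1 of the 2 values shown sits). Compound 3 `O=c1nc(N2CCN(NCc3ccc(OC(F)(F)F)cc3)CC2)sc2c([N+](=O)[O-])cc(C(F)(F)F)cc12` differs from compound 1 in one place: 4-(trifluoromethoxy)benzyl in place of cyclohexyl on an amine nitrogen. Within the data shown here, the only measured step that bears on this change, an at least 2.1-fold lower number from compound 1 to compound 2 (0.33 log units; beyond the scatter), also replaces cyclohexyl on an amine nitrogen and moved the number down. A downward step of comparable size is therefore expected in this assay; the expected step is an at least 2.5-fold lower number from compound 1 to compound 3 (0.40 log units; beyond the scatter). Compound 3 is expected to give 25 ug/mL, within a range from 10 ug/mL to 64 ug/mL.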

Compound 3, half-maximal cytotoxic concentration: > 64 ug/mL
Compound 3 was reported as a limit (the forecaster's own chance of this, stated with the estimate: 25%); at least 2.5-fold (0.40 log units) between middle value and limit.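

In this assay compound 3 gives > 64 ug/mL, which is a limit of the assay and not a number. On the saturated chain carbon bound to an amine nitrogen, 4-(trifluoromethoxy)phenyl in place of cyclohexyl gives an at least 2.1-fold higher number from compound 2 to compound 3 (0.33 log units; beyond the scatter), so the lower number of compound 2 does not follow from the added chain carbon alone, and the ring carried on that carbon also counts. The step from compound 1 to compound 3 cannot be read, and the two compounds cannot be ordered: the limit of > 64 ug/mL in this assay, at which 2 of the 3 values shown sit.

From the compounds shown here alone, how far compound 1 and compound 3 lie beyond that limit remains open. Also open, going by these compounds, is whether an unsubstituted benzyl, a 4-methoxybenzyl or a cyclohexylethyl group on this amine nitrogen would keep the number at the limit or bring it down towards that of compound 2.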